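Swapping the benzyl aryl group: compound 3 to compound 4

The source may hold more compounds than are shown below. What is called first, only, known or untested is meant among the compounds shown, and "the series" means these compounds.

Three compounds of the series have numbers in a functional assay on CHO cells for antagonist activity at prostaglandin E2 receptor EP4 subtype (Homo sapiens), read by calcium flux, with a stated time of 15 min; on this read-out lower numbers stand for stronger inhibition and higher numbers for weaker inhibition. Compound 1 `C[C@H](NC(=O)c1c(C(F)(F)F)nnn1Cc1cccc(C(F)(F)F)c1)c1ccc(C(=O)O)cc1` gives 1970 nM, compound 2 `C[C@H](NC(=O)c1c(C(F)(F)F)nnn1CCOc1ccc(F)cc1)c1ccc(C(=O)O)cc1` gives 276 nM, and compound 3 `C[C@H](NC(=O)c1c(-c2ccccc2)nnn1Cc1cccc(C(F)(F)F)c1)c1ccc(C(=O)O)cc1` gives 23 nM. Compound 3 thus stands lowest of the three, with compound 2 the nearest and compound 1 the furthest. The steps that separate them are an 86-fold lower number from compound 1 to compound 3 (1.93 log units; beyond the scatter) and a 7.1-fold lower number from compound 1 to compound 2 (0.85 log units; beyond the scatter).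

Compound 4 `COc1ccc(Cn2nnc(-c3ccccc3)c2C(=O)N[C@@H](C)c2ccc(C(=O)O)cc2)cc1F` is the next member, not yet measured in this assay. It differs from compound 3 by 3-fluoro-4-methoxyphenyl in place of 3-(trifluoromethyl)phenyl on a saturated chain carbon bound to an aromatic nitrogen. Among the measured compounds shown here, the only measured step at that place is the one from compound 1 to compound 2, which also exchanges the aryl group on the saturated chain carbon bound to the aromatic nitrogen and gave a modest fall in the number; it does not, however, put in the same group that enters here, so it bears on the direction only loosely. Compound 4 is therefore expected to land near compound 3, the step of a 1.1-fold higher number from compound 3 to compound 4 (0.04 log units; within the scatter) estimated to sit within the scatter or at most a small shift in either direction. Compound 4 is estimated at 25 nM, with a range from 8 nM to 80 nM in this assay.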

Compound 4, half-maximal inhibitory concentration: 29.8 nM
Compound 4: middle estimate off by 1.2-fold (0.08 log units), on the low side, within the range that was stated.
By their numbers in this assay, from the lowest: compounds 3 and 4 (each within the scatter of the next); then compound 2; then compound 1.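

In this assay, with phenyl on the aromatic carbon, the step to 3-fluoro-4-methoxyphenyl from 3-(trifluoromethyl)phenyl is a 1.3-fold higher number from compound 3 to compound 4 (0.11 log units; within the scatter) and leaves the two compounds indistinguishable. Trifluoromethyl on this aryl ring is therefore not required for a value of this order in this pair, and an aryl group with a different substitution pattern is accepted at the saturated chain carbon bound to an aromatic nitrogen. The earlier step at this place, a 7.1-fold lower number from compound 1 to compound 2 (0.85 log units; beyond the scatter), came with trifluoromethyl on the aromatic carbon and a (4-fluorophenoxy)methyl group, so it did not show this. Nothing measured here explains why the two aryl groups read alike.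

The compounds shown do not separate the contributions of the fluoro and methoxy groups within the entering aryl group. From the compounds shown here alone, it also remains open how a nitrile or an amine on that ring, or a longer chain in place of the benzyl carbon, would read.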